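Fluoro on the aryl ring across two related cores

The source may hold more compounds than are shown below. What is called first, only, known or untested is meant among the compounds shown, and "the series" means these compounds.

Measured so far in a functional assay on the whole organism with Scenedesmus acutus as the target, read by spectrophotometry; a lower number here means a stronger inhibitor, a higher number a weaker inhibitor:
- compound 1, `S=c1n(-c2ccc(Cl)cc2)c(=S)n2n1CCCC2`: compound 1 gives 43.7 nM
- compound 2, `Fc1cc(Cl)ccc1-n1c(=S)n2n(c1=S)CCCC2`: compound 2 gives 18.2 nM
- compound 3, `S=c1s/c(=N\c2ccc(Cl)cc2)n2n1CCCC2`: compound 3 gives 234 nM

Compound 1 and compound 3 are built from the same atoms joined differently; the difference between the two cores is not broken down here. Compound 3 stands highest of the three measured numbers, beyond the scatter from both others.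

Compound 2 carries, relative to compound 1, (fluoro in place of hydrogen on an aromatic carbon). This gave a 2.4-fold lower number from compound 1 to compound 2 (0.38 log units; beyond the scatter).

Compound 4, `Fc1cc(Cl)ccc1/N=c1\sc(=S)n2n1CCCC2`, is not yet measured. Relative to compound 3 it carries fluoro in place of hydrogen on an aromatic carbon, the same change in the same place, now on the core of compound 3. Among the measured compounds shown here, only one instance of the change has been measured, so there is no check that it carries across cores. The expectation for compound 4 in this assay is a 2.3-fold lower number from compound 3 to compound 4 (0.37 log units; beyond the scatter), resting on the step of a 2.4-fold lower number from compound 1 to compound 2 (0.38 log units; beyond the scatter). Compound 4 is estimated at 100 nM, expected to fall between 50 nM and 250 nM, the bounds kept wide since the shift may not transfer.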

Compound 4, half-maximal inhibitory concentration: 67.6 nM
The estimate for compound 4 lay 1.5-fold (0.17 log units) above the measured number, within the range that was stated.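

In this assay, fluoro in place of hydrogen on an aromatic carbon, ortho to a large group and meta to a chloro group, gave a 3.5-fold lower number from compound 3 to compound 4 (0.54 log units; beyond the scatter) on the core of compound 3, the same direction as on the core of compound 1. This shows the change carrying from one core to the other in this series, but with just these two cores and one aryl pattern, it gives no assurance for any further core and no explanation of the shift. The two steps agree in size as well as direction: the same change on two cores in this assay, a 2.4-fold lower number (0.38 log units; beyond the scatter) from compound 1 to compound 2 and a 3.5-fold lower number (0.54 log units; beyond the scatter) from compound 3 to compound 4, 1.4-fold (0.16 log units) apart, within the scatter of two such steps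

The compounds shown leave open whether the shift is particular to fluoro or would also appear with a methyl group, a methoxy group or a nitrile in the same place on either core. Also open, on these data alone, is whether it survives when the chloro group is exchanged for bromo or trifluoromethyl, since every compound here keeps the chloro group.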